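Growth inhibition series: propoxycarbonyl against benzyloxycarbonyl

This account rests on a few compounds, and the source may have more. Where it says the series, first, only, none or still open, it means among the compounds named here.

Compound 1 `CCCOC(=O)N1N=C(c2ccccc2)CC1c1cc(OC)c(OC)c(OC)c1` was run in a functional assay on HepG2 cells (Homo sapiens) for antiproliferative activity, read by MTT assay, with a stated time of 48 h; on this read-out higher numbers stand for weaker inhibition of growth and lower numbers for stronger inhibition of growth. Compound 1 reaches only the assay limit, > 10000 nM. Compound 2 `COc1cc(C2CC(c3ccccc3)=NN2C(=O)OCc2ccccc2)cc(OC)c1OC` carries phenyl in place of ethyl on a saturated chain carbon bound to an oxygen next to a carbonyl group. In this assay compound 2 likewise stops at the limit, > 10000 nM. The step that the two limits leave unreadable from compound 1 to compound 2 therefore cannot be sized because of the limit of > 10000 nM in this assay, at which 3 of the 3 values shown sit. Compound 3 `CCCOC(=O)N1N=C(c2ccc(OC)cc2)CC1c1cc(OC)c(OC)c(OC)c1` differs from compound 1 by methoxy in place of hydrogen on an aromatic carbon. In this assay compound 3 again gives only the limit, > 10000 nM, so the step that the two limits leave unreadable from compound 1 to compound 3 is unreadable as well. Compound 4 `COc1ccc(C2=NN(C(=O)OCc3ccccc3)C(c3cc(OC)c(OC)c(OC)c3)C2)cc1` remains to be measured; it differs from compound 3 by phenyl in place of ethyl on a saturated chain carbon bound to an oxygen next to a carbonyl group, the same change as that from compound 1 to compound 2. With every measured value sitting at the limit, the step that the limit leaves unreadable from compound 3 to compound 4 is expected to stay unreadable. Compound 4 is estimated at 15000 nM in this assay, most probably reported once more as a limit.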

Compound 4, concentration for 50% growth inhibition: > 10000 nM
Compound 4: no number, only a limit; the forecaster's own chance of this, stated with the estimate: 80%; the middle value does not contradict the limit.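

Compound 4 also gives only a limit, > 10000 nM, so no new step can be read from compound 2 or compound 3 to compound 4: the limit of > 10000 nM in this assay, at which 4 of the 4 values shown sit.

As far as these compounds go, whether benzyloxycarbonyl in place of propoxycarbonyl, or methoxy in place of hydrogen, changes growth inhibition at all in this assay stays open.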